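This account rests on a few compounds, and the source may have more. Where it says the series, first, only, none or still open, it means among the compounds named here.

Working notes on the series.

Three compounds have been run in an assay for inhibition of acyl-CoA:cholesterol acyltransferase (Oryctolagus cuniculus), using microsomes; a higher number here means a weaker inhibitor, a lower number a stronger inhibitor. Compound 1 `CCCCCCCCCCC(C)(C)C(=O)Nc1c(C)c(N)c(C)c2c1OC(C)(C)C2` gives 59 nM. Compound 2 `CCCCCCCCCCCCCCCC(=O)Nc1cccc2c1OC(C)(C)C2` gives 890 nM. Compound 3 `CCCCCCCCCCC1(C(=O)Nc2cccc3c2OC(C)(C)C3)CCCC1` gives 500 nM. Compound 3 thus stands second highest of the three numbers: its nearest neighbour is compound 2, whose number lies within the scatter of that of compound 3, so no order between the two can be read; its furthest is compound 1, whose number sits beyond the scatter below that of compound 3.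

Compound 4 `CCCCCCCCCCC1(C(=O)Nc2c(C)ccc3c2OC(C)(C)C3)CCCC1` is not yet measured. It differs from compound 3 by methyl in place of hydrogen on an aromatic carbon, a methyl in place of hydrogen on an aromatic carbon, ortho to a large group. Among the measured compounds shown here, no pair of measured compounds differing in a single place is available, so the size of the step is not known from this set. A small step toward a lower number is expected in this assay, resting on compound 1, which carries methyl groups on its aromatic ring and gives 59 nM, though compound 1 differs from compound 3 in more than one place.

For compound 4 the expected step is a 2.0-fold lower number from compound 3 to compound 4 (0.30 log units; within the scatter). The estimate for compound 4 in this assay is 250 nM, with a range from 80 nM to 800 nM.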

Compound 4, half-maximal inhibitory concentration: 240 nM
Compound 4: middle estimate off by 1.0-fold (0.02 log units), on the high side; the measured number falls inside the stated range.
By their numbers in this assay, from the lowest: compound 1; then compound 4; then compounds 3 and 2 (each within the scatter of the next).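

Among the compounds shown here, the pair gives the first single-place step: methyl in place of hydrogen on an aromatic carbon, ortho to a large group, gives a 2.1-fold lower number from compound 3 to compound 4 (0.32 log units; beyond the scatter) in this assay and so lies just past the usual noise. This position therefore takes a methyl with a modest gain, which compound 1, differing from compound 3 in more than one place, could not show on its own. Nothing measured here explains the step.

Still open, going by these compounds, is whether a methoxy group or a chlorine at this same position would give a step of similar size or direction. Also open, on these data alone, is whether the methyl step carries over to other acyl groups, and what share of the value of compound 1 belongs to its other ring substituents.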